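Methylphenyl isomer swap on the amide-type nitrogen

The compounds below may be only part of what the source reports. "The series", "measured", "known", "first", "only" and "open" are said of these compounds alone.

Compound 2 `Cc1ccc(NC(=O)C2(C(=O)Nc3ccc(Nc4ncc(F)c(-c5cc(F)c6nc(C)n(C(C)C)c6c5)n4)cc3)CC2)cc1` carries 4-methylphenyl on an amide-type nitrogen and gives 16 nM in a functional assay on T47D cells (Homo sapiens) for antiproliferative activity, read by CCK-8 assay, with a stated time of 72 h; on this read-out higher numbers stand for weaker inhibition and lower numbers for stronger inhibition. Compound 1 `Cc1nc2c(F)cc(-c3nc(Nc4ccc(NC(=O)C5(C(=O)Nc6cccc(F)c6)CC5)cc4)ncc3F)cc2n1C(C)C`, with 3-fluorophenyl in that place, gives 29.3 nM in this assay. Compound 2 holds the lowest of the two numbers, but the step of a 1.8-fold lower number from compound 1 to compound 2 (0.26 log units; within the scatter) leaves the two compounds within the scatter, so no order between them is claimed. Compound 3 `Cc1cccc(NC(=O)C2(C(=O)Nc3ccc(Nc4ncc(F)c(-c5cc(F)c6nc(C)n(C(C)C)c6c5)n4)cc3)CC2)c1` differs from compound 2 only in that (3-methylphenyl in place of 4-methylphenyl on an amide-type nitrogen). For the measured compounds named here, one measured step bears on this position, and its size, a 1.8-fold lower number from compound 1 to compound 2 (0.26 log units; within the scatter), was within the scatter; nothing measured separates the two methylphenyl isomers directly. The expectation is therefore that a 1.3-fold higher number from compound 2 to compound 3 (0.10 log units; within the scatter) stays within the scatter, in neither direction beyond it. Compound 3 is estimated at 20 nM in this assay, with a range from 8 nM to 50 nM.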

Compound 3, half-maximal inhibitory concentration: 203 nM
Beside the measured number, compound 3's estimate is 10-fold (1.01 log units) below it; the whole stated range lies below it.
By their numbers in this assay, from the lowest: compounds 2 and 1 (each within the scatter of the next); then compound 3.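

The swap gives a 13-fold higher number from compound 2 to compound 3 (1.10 log units; beyond the scatter) in this assay, so this position, which looked flat after the first step, separates two groups with the same atoms, joined differently. Methyl in place of fluoro on the aromatic carbon gives a 6.9-fold higher number from compound 1 to compound 3 (0.84 log units; beyond the scatter), so a group named at the 3-position of the phenyl does not by itself set the number: 3-fluorophenyl in compound 1 and 3-methylphenyl in compound 3 lie beyond the scatter of each other. Nothing available explains why 3-methylphenyl stands apart from the other two groups.

Open, going by these compounds, is whether unsubstituted phenyl, 4-fluorophenyl or 3-chlorophenyl would fall with compound 2 or with compound 3. With so few aryl groups shown, the reach of this difference beyond these three compounds also remains open.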